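The source may hold more compounds than are shown below. What is called first, only, known or untested is meant among the compounds shown, and "the series" means these compounds.

Compound 1 `CC(C)c1cccc(C(C)C)c1OC(=O)NC(=O)OCc1ccccc1` and compound 2 `CCCCCCCCSC(=O)NC(=O)Oc1c(C(C)C)cccc1C(C)C` share a common core and were both tested in an assay on microsomes from intestine for inhibition of acyl-CoA:cholesterol acyltransferase (Oryctolagus cuniculus); a lower number here means a stronger inhibitor, a higher number a weaker inhibitor. In that assay compound 1 gives 77 nM. Compound 2 gives 160 nM. Among the measured compounds shown here, the single step connecting them, a 2.1-fold higher number from compound 1 to compound 2 (0.32 log units; beyond the scatter), exchanges the group attached to the carbonyl carbon. Among the two numbers shown, compound 2 stands at the higher one, with compound 1 as its only neighbour.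

Compound 3 `CCCCCCCCCCCCSC(=O)NC(=O)Oc1c(C(C)C)cccc1C(C)C` has not yet been measured. It differs from compound 2 by butyl in place of hydrogen on a saturated chain carbon, eight bonds along the chain from a sulfur, so the chain attached to the sulfur becomes longer. For the measured compounds named here, no measured step alters the length of this chain; the only step known, a 2.1-fold higher number from compound 1 to compound 2 (0.32 log units; beyond the scatter), concerns a different group on the carbonyl carbon, and so bears only loosely on compound 3. Going by the values given here, with nothing among the measured compounds pointing in a direction, the expected step of a 1.5-fold lower number from compound 2 to compound 3 (0.16 log units; within the scatter) is taken as small, within or barely beyond the scatter. Compound 3 is therefore estimated at 110 nM, with a range from 40 nM to 320 nM.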

Compound 3, half-maximal inhibitory concentration: 16 nM
Beside the measured number, compound 3's estimate is 6.9-fold (0.84 log units) above it; the measured number lies below the stated range.
By their numbers in this assay, from the lowest: compound 3; then compound 1; then compound 2.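

The chain on the sulfur proves to be a place where this assay responds clearly to length alone: butyl in place of hydrogen on a saturated chain carbon, eight bonds along the chain from a sulfur, gives a 10-fold lower number from compound 2 to compound 3 (1.00 log units; beyond the scatter) and this step lies beyond the scatter. The earlier step, a 2.1-fold higher number from compound 1 to compound 2 (0.32 log units; beyond the scatter), exchanged the whole group on the carbonyl carbon and so could not separate the length of the chain from the other differences between the two groups, whereas here the sulfur, the carbonyl and the shared core all stay the same and only the chain grows. No measurement among those shown accounts for this drop in the number.

With only two chain lengths on the sulfur, the compounds shown cannot tell whether the number falls steadily with each added carbon or drops at one particular length, nor whether a longer chain would lower it further or raise it again. They also leave open how the position would respond to a chain ending in a phenyl ring, an amine or a carboxylic acid.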